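Swapping Isopropyl for Phenyl on the Chain Carbon

This account rests on a few compounds, and the source may have more. Where it says the series, first, only, none or still open, it means among the compounds named here.

Measured so far in a functional assay on CHO cells for antagonist activity at transient receptor potential cation channel subfamily V member 1 (Rattus norvegicus); on this read-out higher numbers stand for weaker inhibition and lower numbers for stronger inhibition:
compound 1 `CCC(NC(=S)NCc1ccc(C(C)(C)C)cc1)c1ccc(NS(C)(=O)=O)c(F)c1` gives 54 nM
compound 2 `CC(C)C(NC(=S)NCc1ccc(C(C)(C)C)cc1)c1ccc(NS(C)(=O)=O)c(F)c1` gives 223 nM

Within the data shown here, compound 2 stands highest of these two numbers, the only step between them being a 4.1-fold higher number from compound 1 to compound 2 (0.62 log units; beyond the scatter). Compound 3 `CC(C)(C)c1ccc(CNC(=S)NC(c2ccccc2)c2ccc(NS(C)(=O)=O)c(F)c2)cc1` differs from compound 2 by phenyl in place of isopropyl on a saturated chain carbon bound to an amide-type nitrogen and an aromatic carbon. Among the measured compounds shown here, that single step is the only guide, and it concerns enlarging a branch elsewhere, so it bears only loosely on this change. For the measured compounds named here, with no closer precedent, compound 3 is expected near the value of its parent, estimated at 300 nM within 100 nM to 1000 nM, meaning a 1.3-fold higher number from compound 2 to compound 3 (0.13 log units; within the scatter) in this assay.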

Compound 3, inhibition constant: 860 nM
For compound 3 the middle estimate is 2.9-fold (0.46 log units) below the measured one; the measured number falls inside the stated range.
By their numbers in this assay, from the lowest: compound 1; then compound 2; then compound 3.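

In this assay, phenyl on this chain carbon gives a weaker result than isopropyl (a 3.9-fold higher number from compound 2 to compound 3 (0.59 log units; beyond the scatter)), so an aromatic ring here does not recover what was lost on going from ethyl to isopropyl. Against ethyl, the same position shows a much larger change (a 16-fold higher number from compound 1 to compound 3 (1.20 log units; beyond the scatter)), and the numbers rise in the order ethyl, isopropyl, phenyl. No measurement at hand accounts for this rise. Going by these compounds, whether methyl would bring the number lower than ethyl stays open, as does how a longer chain such as propyl would behave here.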